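From a 4-chlorophenyl Amide to a Cyclohexyl Amide

The source may report more compounds than this note shows. Statements on the series, on what has been measured and on what is new or still open speak of the compounds shown alone.

Three close relatives of one shared core have been measured in a physicochemical assay for solubility, read by HPLC; a lower number here means a less soluble compound, a higher number a more soluble compound. Compound 1 `O=C(c1ccccc1F)N1CCN(c2nc(=O)c3cc(C(F)(F)F)cc([N+](=O)[O-])c3s2)CC1` gives 3.1 ug/mL. Compound 2 `O=C(c1ccc(Cl)cc1)N1CCN(c2nc(=O)c3cc(C(F)(F)F)cc([N+](=O)[O-])c3s2)CC1` gives 5.19 ug/mL, and compound 3 `O=C(c1ccccc1Cl)N1CCN(c2nc(=O)c3cc(C(F)(F)F)cc([N+](=O)[O-])c3s2)CC1` gives 8.18 ug/mL. On these numbers compound 2 lies in the middle of the three, yet both gaps are within the scatter: a 1.7-fold higher number from compound 1 to compound 2 (0.22 log units; within the scatter) and a 1.6-fold higher number from compound 2 to compound 3 (0.20 log units; within the scatter). For the measured compounds named here, only the step of a 2.6-fold higher number from compound 1 to compound 3 (0.42 log units; beyond the scatter) reaches beyond the scatter, and it is modest.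

Compound 4 `O=C(C1CCCCC1)N1CCN(c2nc(=O)c3cc(C(F)(F)F)cc([N+](=O)[O-])c3s2)CC1` differs from compound 2 in one place: cyclohexyl in place of 4-chlorophenyl on a carbonyl carbon. Two of the measured steps swap the whole ring on this same carbonyl carbon, and neither moved the number beyond the scatter; the third changes a single atom on that ring and moved it only modestly. Going by the values given here, no measured compound carries a non-aromatic ring in this position, so nothing here shows what such a ring does. The expected step in this assay is therefore a 1.5-fold higher number from compound 2 to compound 4 (0.19 log units; within the scatter), with no confident direction beyond the scatter. Compound 4 is estimated at 8 ug/mL, in the range 3 ug/mL to 20 ug/mL.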

Compound 4, solubility: 3.24 ug/mL
For compound 4 the middle estimate is 2.5-fold (0.39 log units) above the measured one, within the range that was stated.
By their numbers in this assay, from the lowest: compounds 1, 4, 2 and 3 (each within the scatter of the next, the first and the last beyond it).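

For the compounds shown here, the cyclohexyl of compound 4 is the first non-aromatic ring on this carbonyl carbon, and in this assay the change from an aromatic ring gives a 1.6-fold lower number from compound 2 to compound 4 (0.20 log units; within the scatter) and a 1.0-fold higher number from compound 1 to compound 4 (0.02 log units; within the scatter) so an aromatic ring is not needed here for a number in this range. Only the 2-chlorophenyl amide stands apart, with a 2.5-fold lower number from compound 3 to compound 4 (0.40 log units; beyond the scatter) and that step is beyond the scatter but modest. No supporting measurement is available to explain any of these steps.

Going by these compounds, what an open-chain group on this carbonyl carbon, such as a longer alkyl chain, would do remains unknown. On these data alone, it is equally open whether adding an amine or a carboxylic acid to the cyclohexyl ring would move the number beyond the scatter in this assay and thus beyond what these four close relatives show.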